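A few compounds are considered here, and "the series" means these few. Any claim that something is new, unique, unknown or untested is made for them only; others in the source may bear on it.

Compound 3 `O=C(NC/C=C1\CCCc2cnn(Cc3ccc(Cl)cc3Cl)c21)NS(=O)(=O)c1ccc(Cl)cc1` gives 12 nM in a functional assay on CHO-K1 cells for antagonist activity at prostaglandin E2 receptor EP3 subtype (Homo sapiens), read by TR-FRET and cAMP accumulation, with a stated time of 30 min (a higher number here means a weaker inhibitor, a lower number a stronger inhibitor), the highest of the three numbers recorded so far, though compound 2 `COc1ccc(Cl)cc1S(=O)(=O)NC(=O)NC/C=C1\CCCc2cnn(Cc3ccc(Cl)cc3Cl)c21` at 8 nM sits within the scatter of it, and only compound 1 `O=C(NS(=O)(=O)c1cc(Cl)c(Cl)s1)OC/C=C1\CCCc2cnn(Cc3ccc(Cl)cc3Cl)c21` at 5 nM lies beyond the scatter on the lower side. Compound 4 `COc1ccc(S(=O)(=O)NC(=O)NC/C=C2\CCCc3cnn(Cc4ccc(Cl)cc4Cl)c32)cc1` differs from compound 3 by methoxy in place of chloro on an aromatic carbon. Among the measured compounds shown here, the one measured step that touches the group on the sulfonyl sulfur, a 1.5-fold higher number from compound 2 to compound 3 (0.18 log units; within the scatter), exchanged that whole group and moved the number only within the scatter. Compound 1 carries a different group there and a different linker as well, so its value alone cannot be tied to a single change. The exchange of one substituent in compound 4 is therefore expected to give a 1.5-fold higher number from compound 3 to compound 4 (0.18 log units; within the scatter), a move likely to stay within the scatter. Compound 4 is estimated at 18 nM, with a range from 6 nM to 55 nM.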

Compound 4, half-maximal inhibitory concentration: 29 nM
Compound 4: the middle estimate sits 1.6-fold (0.21 log units) below what was measured; the measured number falls inside the stated range.
By their numbers in this assay, from the lowest: compounds 1, 2 and 3 (each within the scatter of the next, the first and the last beyond it); then compound 4.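

At this aromatic carbon, para to a large group, a single exchange of methoxy for chloro gives a 2.4-fold higher number from compound 3 to compound 4 (0.38 log units; beyond the scatter), so the substituent here matters in a way the earlier comparison did not show. Replacing the whole group on the sulfonyl sulfur gives a 3.6-fold higher number from compound 2 to compound 4 (0.56 log units; beyond the scatter), whereas the exchange with the 4-chlorophenyl group gave only a 1.5-fold higher number from compound 2 to compound 3 (0.18 log units; within the scatter). No measurement shown explains this difference. Still open, on these data alone, is whether fluoro, an amine or a hydroxyl at this carbon would hold the number near that of compound 3, and whether methoxy has the same effect with the linker of compound 1.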